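A Stereochemical Flip on a Methoxy-Bearing Diol

A few compounds are considered here, and "the series" means these few. Any claim that something is new, unique, unknown or untested is made for them only; others in the source may bear on it.

Compound 1 `Oc1ccc(CC[C@H](O)C[C@@H](O)CCc2ccccc2)cc1` gives 56.3 ug/mL in a functional assay on A-375 cells (Homo sapiens) for antiproliferative activity, read by MTT assay, with a stated time of 48 h; on this read-out lower numbers stand for stronger inhibition and higher numbers for weaker inhibition.
Compound 2 `Oc1ccc(CC[C@@H](O)C[C@@H](O)CCc2ccccc2)cc1` gives 57.8 ug/mL.
Compound 3 `COc1cc(CC[C@H](O)C[C@@H](O)CCc2ccccc2)ccc1O` gives 69.1 ug/mL.

Among these three, compound 3 shows the highest number, yet its gap to compound 2 and to compound 1 is within the scatter, so no order among them can be claimed. Compound 4 `COc1cc(CC[C@@H](O)C[C@@H](O)CCc2ccccc2)ccc1O` is its configurational partner: the two compounds have the same atoms and bonds and differ only in configuration as drawn: 1 of 2 stereo elements differ; a stereocentre at a saturated chain carbon is drawn S in compound 3 and R in compound 4. The same kind of change was already measured once, from compound 1 to compound 2, where a 1.0-fold higher number from compound 1 to compound 2 (0.01 log units; within the scatter); that comparison rests on (the fact that compounds 1 and 2 differ only in the configuration as drawn). Since that step stayed within the scatter, no step beyond the scatter is expected here either, a 1.0-fold lower number from compound 3 to compound 4 (0.01 log units; within the scatter). Compound 4 is therefore estimated at 68 ug/mL, with a range from 40 ug/mL to 115 ug/mL.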

Compound 4, half-maximal inhibitory concentration: 75.2 ug/mL
The estimate for compound 4 lay 1.1-fold (0.04 log units) below the measured number; the measured number falls inside the stated range.
By their numbers in this assay, from the lowest: compounds 1, 2, 3 and 4 (each within the scatter of the next).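

The flip at this saturated chain carbon now appears on a second core, the one carrying methoxy, and in this assay it again stays within the scatter (a 1.1-fold higher number from compound 3 to compound 4 (0.04 log units; within the scatter)). Methoxy in place of hydrogen on an aromatic carbon also stays within the scatter when the stereocentre is drawn R (a 1.3-fold higher number from compound 2 to compound 4 (0.11 log units; within the scatter)), so this change reads alike on both cores: the same change on two cores in this assay, a 1.2-fold higher number (0.09 log units; within the scatter) from compound 1 to compound 3 and a 1.3-fold higher number (0.11 log units; within the scatter) from compound 2 to compound 4, 1.1-fold (0.03 log units) apart, within the scatter of two such steps.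

As far as these compounds go, the other stereocentre is drawn the same way in all four compounds, so its role stays open. From the compounds shown here alone, whether an amine, a carboxylic acid or a longer chain would move the number beyond the scatter also stays open.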